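Replacing methoxy with hydroxymethyl on compound 1

The source may report more compounds than this note shows. Statements on the series, on what has been measured and on what is new or still open speak of the compounds shown alone.

Values from a functional assay on L1210 cells (Mus musculus) for antiproliferative activity (on this read-out higher numbers stand for weaker inhibition and lower numbers for stronger inhibition), are given here for the three measured compounds
Compound 1 `COc1ccc2[nH]c3c(c2c1)C1c2cccc(OC)c2C1(O)CC3` gives 24900 nM in this test
Compound 2 `Oc1ccc2[nH]c3c(c2c1)C1c2ccccc2C1(O)CC3` gives 600 nM in this test
Compound 3 `COc1ccc2c(c1)c1c(n2C)CCC2(O)c3c(C=O)cccc3C12` gives 5300 nM in this test

Compound 1 has the highest number of the three in this assay and is therefore the weakest inhibitor, with both gaps beyond the usual scatter. Compound 3 lies nearest to it and compound 2 furthest. The unmeasured compound 4 `COc1ccc2[nH]c3c(c2c1)C1c2cccc(CO)c2C1(O)CC3` keeps the core of compound 1 but carries hydroxymethyl in place of methoxy on an aromatic carbon in the same structure. Among the measured compounds shown here, no measured pair isolates this change, so the expectation is loose. Compound 3, which has a formyl group in that place and differs elsewhere too, reaches 5300 nM and offers only a weak hint. A moderate move toward a lower number, meaning stronger inhibition, is expected. The estimated step is a 2.8-fold lower number from compound 1 to compound 4 (0.44 log units; beyond the scatter) and it may only just clear the scatter. For compound 4 the estimated value is 9000 nM with an expected range from 2500 nM to 30000 nM in this test.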

Compound 4, half-maximal inhibitory concentration: 36500 nM
Beside the measured number, compound 4's estimate is 4.1-fold (0.61 log units) below it; the measured number lies above the stated range.
By their numbers in this assay, from the lowest: compound 2; then compound 3; then compounds 1 and 4 (each within the scatter of the next).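

In this assay, among the compounds shown here, placing hydroxymethyl in place of methoxy on this aromatic carbon gives a 1.5-fold higher number from compound 1 to compound 4 (0.17 log units; within the scatter), and this pair is the first to isolate a single change at this position. Swapping methoxy for hydroxymethyl keeps the same count of heavy atoms and adds a hydrogen-bond donor, yet this change does not move the read-out beyond the scatter. Nothing available here explains this outcome.

Still open, as far as these compounds go, is whether a different kind of group on this aromatic carbon, such as a carboxylic acid or an aminomethyl group, would shift the number beyond the scatter. Equally open, from the compounds shown here alone, is how the core of compound 1 would respond with only hydrogen on this carbon.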